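A few compounds are considered here, and "the series" means these few. Any claim that something is new, unique, unknown or untested is made for them only; others in the source may bear on it.

Of the compounds shown here, three that share one core have so far been measured in a functional assay on the whole organism (plasma, strain albino) for inhibition, with Rattus norvegicus as the target, with stated times of 1 h and 4 h, at a dose of 25 mg/kg by the oral route; on this read-out higher numbers stand for a stronger effect at the one dose given and lower numbers for a weaker effect. Compound 1 `COc1ccc(Cl)cc1C(=O)Nc1ccc(C2=NN(C)C(c3ccc([N+](=O)[O-])cc3)C2)cc1` gives 71.4%. Compound 2 `COc1ccc(C2CC(c3ccc(NC(=O)c4cc(Cl)ccc4OC)cc3)=NN2c2ccccc2)cc1` gives 82.3%. Compound 3 `COc1ccc(Cl)cc1C(=O)Nc1ccc(C2=NN(c3ccccc3)C(c3ccccc3[N+](=O)[O-])C2)cc1` gives 73.3% and stands second highest of the three numbers, with compound 1 nearest and compound 2 furthest, both within the scatter, so no order among the three can be claimed. Compound 4 `COc1ccc(Cl)cc1C(=O)Nc1ccc(C2=NN(c3ccccc3)C(c3ccc([N+](=O)[O-])cc3)C2)cc1` has not yet been measured. It differs from compound 3 in one place: 4-nitrophenyl in place of 2-nitrophenyl on a saturated ring carbon. Among the compounds with values here, the only measured step at that same position is a number 9 percentage points lower from compound 2 to compound 3 (within the scatter), which stayed within the scatter. Compound 1 also carries a 4-nitrophenyl on a saturated ring carbon, though at the ring nitrogen it lacks the phenyl group that compound 3 carries, and its number sits close to that of compound 3. From this the expected step is a number 1.7 percentage points higher from compound 3 to compound 4 (within the scatter), nothing beyond the scatter. For compound 4 in this assay the estimate is 75%, expected to lie between 63% and 87%.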

Compound 4, a percentage reported as inhibition, in the whole organism at one dose (the size of the read-out at that dose, not a potency): 75.3%
Beside the measured number, compound 4's estimate is 0.3 percentage points below it; the measured number falls inside the stated range.
By their numbers in this assay, from the lowest: compounds 1, 3, 4 and 2 (each within the scatter of the next, the first and the last beyond it).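

Exchanging 2-nitrophenyl for 4-nitrophenyl on the saturated ring carbon gives a number 2 percentage points higher from compound 3 to compound 4 (within the scatter) in this assay, so here the place of the nitro group on this phenyl ring makes no difference that can be read. With the 4-nitrophenyl kept, nitro in place of methoxy on an aromatic carbon gives a number 7 percentage points lower from compound 2 to compound 4 (within the scatter) and phenyl in place of methyl on the amine nitrogen in the ring gives a number 3.9 percentage points higher from compound 1 to compound 4 (within the scatter), so neither single change separates its pair. No measurement bears on why these steps are this small.

Going by these compounds, whether an amine or a carboxylic acid on that saturated ring carbon, in place of the nitrophenyl, would shift the number beyond the scatter stays open. The same holds for a longer chain on the ring nitrogen.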